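Bromomethyl in place of ethynyl on the amide of compound 3

The compounds below may be only part of what the source reports. "The series", "measured", "known", "first", "only" and "open" are said of these compounds alone.

Compound 1, `C/C=C/C(=O)N(Cc1cc(OC)c(OC)c(OC)c1)c1ccc(OC)c(O)c1`, gives 9160 nM in a functional assay on KYSE-450 cells (Homo sapiens) for inhibition, read by MTT assay, with a stated time of 48 h; on this read-out higher numbers stand for weaker inhibition and lower numbers for stronger inhibition.
Compound 2, `COc1ccc(CNc2cc(OC)c(OC)c(OC)c2)cc1Br`, gives 39800 nM in this assay.
Compound 3, `C#CC(=O)N(Cc1ccc(OC)c(O)c1)c1cc(OC)c(OC)c(OC)c1`, gives 570 nM in this assay.

Of the three numbers shown, compound 3 has the lowest. Compound 1 comes nearest to it, though the gap already lies beyond the usual scatter of repeated measurements, and compound 2 stands furthest away, also well beyond the scatter. For the measured compounds named here, none of the three measured compounds differs from another in a single place, so no isolated step between measured compounds is available to lean on.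

Compound 4, `COc1ccc(CN(C(=O)CBr)c2cc(OC)c(OC)c(OC)c2)cc1O`, has not yet been measured in this assay. Set against compound 3, it changes in one spot: bromomethyl in place of ethynyl on a carbonyl carbon. The change sits on a carbonyl carbon whose other neighbour is the amide-type nitrogen, and the rest of compound 3 is kept as it is.

Going by the values given here, with no measured pair that isolates this kind of exchange, the expectation rests on the rest of compound 3 being unchanged. The step from compound 3 to compound 4 is expected to stay within the scatter, a 1.1-fold higher number from compound 3 to compound 4 (0.02 log units; within the scatter). Compound 4 is therefore estimated at 600 nM in this assay, within a range from 150 nM to 2500 nM.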

Compound 4, half-maximal inhibitory concentration: 120 nM
Compound 4: the middle estimate sits 5.0-fold (0.70 log units) above what was measured; measured number outside the range, below it.
By their numbers in this assay, from the lowest: compound 4; then compound 3; then compound 1; then compound 2.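

In this assay, putting bromomethyl in place of ethynyl on the carbonyl carbon gives a 4.8-fold lower number from compound 3 to compound 4 (0.68 log units; beyond the scatter), a modest step but one beyond the scatter, and the first in this set to isolate a single change. It shows that this position responds to what it carries: with the rest of compound 3 kept as it is, the ethynyl group can leave without any loss of inhibition, and the number falls instead. Nothing given here accounts for the size or direction of this step.

From the compounds shown here alone, what remains open is whether the step depends on the bromine atom or simply on the loss of the triple bond, a question that a chloromethyl or a plain methyl group on the same carbonyl carbon would help to settle. Going by these compounds, it is also open whether the same exchange would give a step of similar size on another core, such as that of compound 1, whose carbonyl carbon carries a different group.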